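The source may hold more compounds than are shown below. What is called first, only, known or untested is meant among the compounds shown, and "the series" means these compounds.

Going by the values given here, compound 1, `CCOC(=O)C1=C(Nc2ccccc2)S/C(=C\c2ccc[nH]2)C1=O`, is the only compound here with a full number: in a functional assay on MCF7 cells (Homo sapiens) for inhibition, read by MTT assay, with a stated time of 72 h, tested at 10 uM (on this read-out higher numbers stand for more inhibition at the one concentration tested (going by the name of the read-out) and lower numbers for less inhibition), compound 1 gives 18.3%. Compound 2, `CCOC(=O)C1=C(Nc2ccc(OC)cc2)S/C(=C\c2ccc[nH]2)C1=O`, carries a methoxy group on an aromatic carbon where compound 1 carries hydrogen. In this assay compound 2 returns only a limit of the assay, < 10%, so where compound 2 stands is known only as a range rather than a number. Among the compounds with values here, the step from the first compound to the second is a number at least 8.3 percentage points lower from compound 1 to compound 2 (that floor lies within the scatter), which rests on (the limit of < 10% in this assay, at which 1 of the 2 values shown sits). Compound 3, `CCOC(=O)C1=C(Nc2ccc(Br)cc2)S/C(=C\c2ccc[nH]2)C1=O`, has not yet been measured in this assay. It differs from compound 2 by bromo in place of methoxy on an aromatic carbon. Within the data shown here, the single measured step, methoxy in place of hydrogen, does not match this change, so no measured step bears on it directly; both measured compounds sit low, and compound 2 rests at a limit. The expected step is a number at least 2 percentage points higher from compound 2 to compound 3 (that floor lies within the scatter), with no direction expected beyond the scatter. Compound 3 is therefore estimated at 12%, expected to fall between 4% and 26%.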

Compound 3, a percentage reported as inhibition, at one concentration (the size of the read-out at that concentration, not a potency): < 10%
Compound 3: a limit, no number; the forecaster's own chance of this, stated with the estimate: 45%; middle value at least 2 percentage points away from the limit.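

With bromo in the place that held methoxy, this assay again gives only a limit for compound 3, < 10%, so a second group at this position, with a different atom attached to the ring, also fails to yield a full number. Bromo in place of hydrogen on the same aromatic carbon gives a number at least 8.3 percentage points lower from compound 1 to compound 3 (that floor lies within the scatter), and since this floor lies within the usual scatter, the step alone does not establish a real loss of inhibition, even though compound 1, carrying hydrogen, remains the only compound with a full number. The step between the methoxy and bromo compounds cannot be read, because both compounds rest at the same limit, so nothing can be said about how these two groups compare: the limit of < 10% in this assay, at which 2 of the 3 values shown sit.

The compounds shown leave open whether a quite different group at this position, such as an amine or a carboxylic acid, would give a full number rather than a limit, and whether any group there would exceed the value of compound 1. They also leave open whether methoxy or bromo would behave the same way on another carbon of the six-membered ring.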